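Ester group variation across compounds 1 to 3

This account rests on a few compounds, and the source may have more. Where it says the series, first, only, none or still open, it means among the compounds named here.

Compound 1 `CC(C)(CO)[C@H](O)C(=O)N/C=C/C(=O)OCc1ccccc1` and compound 2 `COC(=O)/C=C/NC(=O)[C@@H](O)C(C)(C)CO` differ only in the ester alkyl group. In an ADME assay on WI-38 cells (Homo sapiens) for inhibition, read by CellTiter-Glo, with a stated time of 48 h, tested at 100 uM (on this read-out lower numbers stand for less inhibition and higher numbers for more inhibition at the one concentration tested (going by the name of the read-out)), compound 1 gives 19%, and compound 2 gives -18%. Within the data shown here, compound 2 therefore stands lowest of the two numbers so far, with compound 1 its nearest neighbour. Among the measured compounds shown here, the single measured step, a number 37 percentage points lower from compound 1 to compound 2 (beyond the scatter), is the only comparison that bears on this part of the molecule. Compound 3 `CC(C)(C)OC(=O)/C=C/NC(=O)[C@@H](O)C(C)(C)CO` is the next member to be measured in this assay; it differs from compound 2 by tert-butyl in place of methyl on an oxygen next to a carbonyl group. Because the step of a number 37 percentage points lower from compound 1 to compound 2 (beyond the scatter) was large when the ester group was trimmed, enlarging the ester group again is expected to move the read-out upward, and the step of a number 18 percentage points higher from compound 2 to compound 3 (beyond the scatter) is expected to be modest rather than a full reversal. Compound 3 is accordingly estimated at 0%, with a range of -20% to 20%.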

Compound 3, a percentage reported as inhibition, at one concentration (the size of the read-out at that concentration, not a potency): 14%
Compound 3: middle estimate off by 14 percentage points, on the low side; measured number inside the range.
By their numbers in this assay, from the lowest: compound 2; then compounds 3 and 1 (each within the scatter of the next).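

Notes on the ester position, in this assay: on an oxygen next to a carbonyl group, tert-butyl in place of methyl gives a number 32 percentage points higher from compound 2 to compound 3 (beyond the scatter) and so restores most of what the earlier step had lost, without any ring in the entering group. Tert-butyl in place of benzyl gives a number 5 percentage points lower from compound 1 to compound 3 (within the scatter) and so leaves these two groups unseparated, which makes compound 2, the methyl ester, the only one of the three that stands apart. No measurement at hand explains either step.

On these data alone, whether a longer straight chain such as n-butyl on this oxygen reads with tert-butyl and benzyl or with methyl remains open, as does the reading of the free carboxylic acid. These are also readings at one concentration, so they give no potency for any of the three compounds.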